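A few compounds are considered here, and "the series" means these few. Any claim that something is new, unique, unknown or untested is made for them only; others in the source may bear on it.

Working notes on the series. Compound 1 `Cc1cccc(F)c1N(C)C(=O)c1ccc(-c2ccc(O)cc2)o1` gives 310 nM in an assay on cytosol from placenta for inhibition of 17-beta-hydroxysteroid dehydrogenase type 1 (Homo sapiens), read by HPLC, with a stated time of 10 min, in the presence of a further agent that is not named here; a higher number here means a weaker inhibitor, a lower number a stronger inhibitor. Compound 2 `Cc1c(F)cccc1N(C)C(=O)c1ccc(-c2ccc(O)cc2)o1` gives 170 nM in this assay. Going by the values given here, the two numbers sit within the scatter of each other, so compound 2 is not set apart from compound 1; the only step measured is a 1.8-fold lower number from compound 1 to compound 2 (0.26 log units; within the scatter). Compound 3 `Cc1cccnc1N(C)C(=O)c1ccc(-c2ccc(O)cc2)o1` differs from compound 2 by 3-methylpyridin-2-yl in place of 3-fluoro-2-methylphenyl on an amide-type nitrogen. Among the compounds with values here, no measured step swaps a carbon-only ring for one with a hetero atom, and the one step in hand was within the scatter, so nothing beyond the scatter is expected: the estimated step is a 1.3-fold higher number from compound 2 to compound 3 (0.11 log units; within the scatter). For compound 3 the expected value in this assay is 220 nM, between 70 nM and 700 nM.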

Compound 3, half-maximal inhibitory concentration: 3300 nM
Compound 3: middle estimate off by 15-fold (1.18 log units), on the low side; the measured number lies above the stated range.
By their numbers in this assay, from the lowest: compounds 2 and 1 (each within the scatter of the next); then compound 3.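

The position on the amide-type nitrogen does not accept every ring: 3-methylpyridin-2-yl gives a large loss against both phenyl groups (a 19-fold higher number from compound 2 to compound 3 (1.29 log units; beyond the scatter); an 11-fold higher number from compound 1 to compound 3 (1.03 log units; beyond the scatter)), whereas the two fluoro-methylphenyl groups stay within the scatter of each other. The change removes fluorine and brings in a ring nitrogen with a hydrogen-bond acceptor in a single step. No measurement shown accounts for the loss.

The compounds shown do not separate the ring nitrogen from the lost fluorine. A methylphenyl group without fluorine, or a fluorinated methylpyridinyl group, would bear on that.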